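Removing a methoxy group from a cinnamic acid ester series

A few compounds are considered here, and "the series" means these few. Any claim that something is new, unique, unknown or untested is made for them only; others in the source may bear on it.

Of the compounds shown here, three sharing one core have been measured in a functional assay on EA.hy 926 cells (Homo sapiens) for cytotoxicity, read by MTT assay, with stated times of 24 h and 12 h; on this read-out higher numbers stand for an effect only at larger amounts of compound and lower numbers for an effect already at smaller amounts. Compound 1 `COc1cc(/C=C/C(=O)O)ccc1OC(=O)c1nc(C)c(C)nc1C` gives 69400 nM, compound 3 `COc1cc(/C=C/C(=O)O)cc(OC)c1OC(=O)c1nc(C)c(C)nc1C` gives 34700 nM, and compound 2 `COc1ccc(/C=C/C(=O)O)cc1OC(=O)c1nc(C)c(C)nc1C` gives 8800 nM, the lowest of the three. Compound 1 arises from compound 3 by the change (hydrogen in place of methoxy on an aromatic carbon), and that step is a 2.0-fold higher number from compound 3 to compound 1 (0.30 log units; within the scatter). The difference between the cores of compound 2 and compound 3 is not broken down here; their values simply show compound 2 with the lower number.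

Compound 4 `Cc1nc(C)c(C(=O)Oc2cccc(/C=C/C(=O)O)c2)nc1C` is not yet measured. Within the data shown here, it arises from compound 2 by the change (hydrogen in place of methoxy on an aromatic carbon), the same kind of change as the one from compound 3 to compound 1, though the surroundings differ: in compound 3 the leaving methoxy is meta to a 2-carboxyethenyl group and meta to a methoxy group, whereas in compound 2 it is para to a 2-carboxyethenyl group. Because the earlier step was a 2.0-fold higher number from compound 3 to compound 1 (0.30 log units; within the scatter), a similarly small step is expected for compound 4, estimated as a 1.7-fold higher number from compound 2 to compound 4 (0.23 log units; within the scatter). Compound 4 is therefore expected to give about 15000 nM in this assay, likely between 5000 nM and 45000 nM.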

Compound 4, half-maximal effective concentration: 24000 nM
Compound 4: the middle estimate sits 1.6-fold (0.20 log units) below what was measured; measured number inside the range.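

Replacing the methoxy group with hydrogen on the core of compound 2 gives a 2.7-fold higher number from compound 2 to compound 4 (0.44 log units; beyond the scatter) in this assay. Set beside the earlier case, the change carries over between these two cores with a similar size: the same change on two cores in this assay, a 2.0-fold higher number (0.30 log units; within the scatter) from compound 3 to compound 1 and a 2.7-fold higher number (0.44 log units; beyond the scatter) from compound 2 to compound 4, 1.4-fold (0.13 log units) apart, within the scatter of two such steps. Among these compounds, this agreement rests on only two pairs of compounds in one cell assay, and only the step on the core of compound 2 lies beyond the scatter, so it does not show that the change would behave the same way on a further core, nor does it explain why either step has the size it has.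

The compounds shown leave open what happens when the methoxy group gives way to something other than hydrogen, such as a hydroxyl group, an amine or a longer alkoxy chain. Going by these compounds, whether the same step would appear on any other read-out also remains open.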